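Difluorobenzyl Pattern Swap on a Pyrazole Amide Series

This account rests on a few compounds, and the source may have more. Where it says the series, first, only, none or still open, it means among the compounds named here.

Measured compounds:
Compound 1 `CC1(C)c2[nH]nc(NC(=O)c3ccccc3)c2CN1Cc1cc(F)cc(F)c1`: 190 nM
Compound 2 `CC1(C)c2[nH]nc(NC(=O)c3ccc4ncccc4c3)c2CN1Cc1cc(F)cc(F)c1`: 180 nM
Compound 3 `CC1(C)c2[nH]nc(NC(=O)c3ccc(F)cc3)c2CN1Cc1cccc(F)c1F`: 210 nM

In an assay on Sf21 cells for inhibition of high affinity nerve growth factor receptor (Homo sapiens), read by HTRF, with a stated time of 30 min, in the presence of a further agent that is not named here (a lower number here means a stronger inhibitor, a higher number a weaker inhibitor), compound 1 gives 190 nM. Among the measured compounds shown here, compound 2 gives 180 nM, and the only step measured within one place, a 1.1-fold lower number from compound 1 to compound 2 (0.02 log units; within the scatter), lies within the scatter. Compound 3 gives 210 nM, the highest of the three numbers, though its gaps to compound 1 and to compound 2 are both within the scatter, so no order among the three can be read.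

Compound 4 `CC1(C)c2[nH]nc(NC(=O)c3ccc(F)cc3)c2CN1Cc1cc(F)cc(F)c1` differs from compound 3 in one place: 3,5-difluorophenyl in place of 2,3-difluorophenyl on a saturated chain carbon bound to an amine nitrogen in a ring. For the measured compounds named here, no measured pair isolates this change. Compound 1 already carries the 3,5-difluorobenzyl group with an unsubstituted benzoyl, and its number sits close to that of compound 3, which differs from it in two places. Going by the values given here, the one measured step, from compound 1 to compound 2, concerns the benzoyl side and was within the scatter, so the series so far shows no step beyond the scatter at all.

Compound 4 is therefore expected to give 200 nM, between 90 nM and 450 nM, an estimated step of a 1.1-fold lower number from compound 3 to compound 4 (0.02 log units; within the scatter) that stays within the scatter.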

Compound 4, half-maximal inhibitory concentration: 350 nM
Estimate against measurement, compound 4: 1.8-fold (0.24 log units) below; the measured number falls inside the stated range.
By their numbers in this assay, from the lowest: compounds 2, 1, 3 and 4 (each within the scatter of the next).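

In this assay, among the compounds shown here, the first measured change at this position, on a saturated chain carbon bound to an amine nitrogen in a ring, is 2,3-difluorobenzyl to 3,5-difluorobenzyl, and it gives a 1.7-fold higher number from compound 3 to compound 4 (0.22 log units; within the scatter) and so does not separate the two fluorine patterns. The other two steps ending at compound 4 stay inside the scatter as well: fluoro in place of hydrogen on an aromatic carbon gives a 1.8-fold higher number from compound 1 to compound 4 (0.27 log units; within the scatter) and 4-fluorophenyl in place of quinolin-6-yl on a carbonyl carbon gives a 1.9-fold higher number from compound 2 to compound 4 (0.29 log units; within the scatter) and thus no single change yet orders the four compounds. No measurement is at hand that could explain these small steps.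

The compounds shown leave open whether any group at either place would give a step beyond the scatter. A 3,5-dichlorophenyl in place of 3,5-difluorophenyl, or a 4-carboxyphenyl on the carbonyl carbon, would test this.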